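The source may hold more compounds than are shown below. What is called first, only, known or untested is meant among the compounds shown, and "the series" means these compounds.

Compound 3 `O=C(NCCO)c1c(NO)cc(-c2ccc(F)cc2)oc1=O` stands at a limit of the assay: in an ADME assay on Huh-7 cells (Homo sapiens) for cytotoxicity, read by a luciferase reporter and WST assay, with a stated time of 3 days (on this read-out higher numbers stand for lower toxicity in this test and lower numbers for higher toxicity in this test), compound 3 gives > 20000 nM. Compound 2 `O=C(NCCO)c1c(NO)cc(-c2ccccc2)oc1=O` likewise returns a limit, > 20000 nM, in this assay. Compound 1 `CNC(=O)c1c(NO)cc(-c2ccc(Cl)cc2)oc1=O` also sits at a limit, giving > 20000 nM in this assay. For the measured compounds named here, the one measured step, a step that the two limits leave unreadable from compound 2 to compound 3, has no readable size, and the limit of > 20000 nM in this assay, at which 3 of the 3 values shown sit, covers every value shown. Compound 4 `O=C(NCCO)c1c(NO)cc(-c2ccc(Cl)cc2)oc1=O` differs from compound 3 by chloro in place of fluoro on an aromatic carbon. Going by the values given here, no measured step gives a readable size for this change, and compound 1, which carries the same 4-chlorophenyl group, sits at the limit as well. Compound 4 is therefore expected to show no step beyond the scatter, a step that the limit leaves unreadable from compound 3 to compound 4, in this assay. Compound 4 is estimated at 25000 nM, with a range from 10000 nM to 60000 nM.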

Compound 4, half-maximal cytotoxic concentration: > 20000 nM
Compound 4: a limit, no number (the forecaster's own chance of this, stated with the estimate: 85%); the middle value lies beyond the limit too.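

For the compounds shown here, compound 4 also returns a limit, so no step from compound 1, compound 2 or compound 3 to compound 4 can be read. The compounds shown leave open where any of their true values lie in this assay, and whether any of these changes shifts them: the limit of > 20000 nM in this assay, at which 4 of the 4 values shown sit.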